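From propylsulfanyl to cyclopropylamino on a shared core

The compounds below may be only part of what the source reports. "The series", "measured", "known", "first", "only" and "open" are said of these compounds alone.

Within the data shown here, in an ADME assay on CCRF-HSB-2 cells (Homo sapiens) for cytotoxicity, with a stated time of 7 days (on this read-out higher numbers stand for lower toxicity in this test and lower numbers for higher toxicity in this test), compound 2 (`CCCSc1nc(N)nc2c1ncn2/C=C1/CC1(CO)CO`) gives 98000 nM as the only exact number so far. Compound 1 (`CCOc1nc(N)nc2c1ncn2/C=C1/CC1(CO)CO`) shows > 20000 nM as a limit of the assay and not a number. Among the measured compounds shown here, the only measured step is a step that the limit leaves unreadable from compound 1 to compound 2 and so offers no size to carry over. Compound 3 (`Nc1nc(NC2CC2)c2ncn(/C=C3/CC3(CO)CO)c2n1`) has cyclopropylamino in place of propylsulfanyl on an aromatic carbon. With no readable guide, the expected step of a 1.4-fold lower number from compound 2 to compound 3 (0.15 log units; within the scatter) is estimated to stay within the usual scatter, in no clear direction. Compound 3 is expected at 70000 nM (estimated range 20000 nM to 200000 nM).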

Compound 3, half-maximal cytotoxic concentration: > 20000 nM
Compound 3: only a limit was reported; the forecaster's own chance of this, stated with the estimate: 45%; the middle value lies beyond the limit too.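

In this assay compound 3 gives > 20000 nM, which is a limit of the assay and not a number. Among these compounds, no step among compound 1, compound 2 and compound 3 can be read. The compounds shown leave open how ethoxy, propylsulfanyl and cyclopropylamino compare on the shared core, with the values resting on: the limit of > 20000 nM in this assay, at which 2 of the 3 values shown sit.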